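Methoxy for Trifluoromethyl: Cytotoxicity Expected to Stay Flat

A few compounds are considered here, and "the series" means these few. Any claim that something is new, unique, unknown or untested is made for them only; others in the source may bear on it.

Three measured compounds share one core and differ in the group attached to the amide and in the aromatic substituent on the other side. Compound 1 `CC(C)Cc1nn(-c2cccc(F)c2)cc1C(=O)NCC1CCN(C(=O)OC(C)(C)C)CC1` carries a protected piperidinylmethyl amide, compound 2 `CC(C)Cc1nn(-c2nccs2)cc1C(=O)NCc1ccc(C(F)(F)F)cc1` a benzylic amide bearing trifluoromethyl, and compound 3 `COc1ccc(CONC(=O)c2cn(-c3cccc(F)c3)nc2CC(C)C)cc1` an oxyamide.

In a toxicity assay on HepG2 2.2.15 cells (Homo sapiens) for cytotoxicity, read by CCK-8 assay, with a stated time of 8 days (a lower number here means that less compound is tolerated, a higher number that more compound is tolerated), compound 1 gives > 100000 nM, which is a limit of the assay and not a number. In this assay compound 2 gives > 100000 nM, again a limit rather than a measured number. In this assay, for the measured compounds named here, compound 3 gives 67900 nM, the only plain number of the three. Compound 2 thus stands at the limit of > 100000 nM in this assay, at which 2 of the 3 values shown sit, and no more can be said of it than that it was tolerated up to that point.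

Compound 4 `COc1ccc(CNC(=O)c2cn(-c3nccs3)nc2CC(C)C)cc1` differs from compound 2 by methoxy in place of trifluoromethyl on an aromatic carbon. Going by the values given here, no pair of measured compounds shows this change on its own, so its effect cannot be read off directly. Because compound 1 and compound 2 both sit at the limit of > 100000 nM in this assay, at which 2 of the 3 values shown sit, no shift beyond the scatter is expected in either direction. The step from compound 2 to compound 4 is estimated at a number no higher from compound 2 to compound 4 (the limit leaves the size open). Compound 4 is expected to give 100000 nM in this assay, with a range from 40000 nM to 300000 nM, and will most likely be reported as a limit again.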

Compound 4, half-maximal cytotoxic concentration: > 100000 nM
Compound 4: only a limit was reported; the forecaster's own chance of this, stated with the estimate: 75%; the middle value sits exactly at the limit.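

In this assay compound 4 gives > 100000 nM, a limit of the assay and not a number. No step from compound 2 to compound 4 can be read, because both stand at a limit: the limit of > 100000 nM in this assay, at which 3 of the 4 values shown sit.

The compounds shown leave open what methoxy in place of trifluoromethyl on an aromatic carbon does to tolerated concentration in this assay.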